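Trifluoromethyl for fluoro, starting from a limit

The source may report more compounds than this note shows. Statements on the series, on what has been measured and on what is new or still open speak of the compounds shown alone.

Measured in a functional assay on SK-OV-3 cells (Homo sapiens) for antiproliferative activity, read by MTT assay, with a stated time of 24 h; a higher number here means a weaker inhibitor, a lower number a stronger inhibitor:
Compound 1 `COc1ccc(C(=O)/C=C/c2cccc(F)c2)c2c1C=CC(C)(C)O2`: > 10000 nM (a limit)
Compound 2 `COc1ccc(C(=O)/C=C/c2ccc(N(C)C)cc2)c2c1C=CC(C)(C)O2`: 2750 nM
Compound 3 `COc1ccc(/C=C/C(=O)c2ccc(OC)c3c2OC(C)(C)C=C3)cn1`: > 10000 nM (a limit)

Compound 1 has no number, only the limit of > 10000 nM. The same holds across most of this small set, which shows (the limit of > 10000 nM in this assay, at which 2 of the 3 values shown sit). Compound 4 `COc1ccc(C(=O)/C=C/c2cccc(C(F)(F)F)c2)c2c1C=CC(C)(C)O2` keeps the core of compound 1 and alters one substituent: trifluoromethyl in place of fluoro on an aromatic carbon. Going by the values given here, the new group is trifluoromethyl in place of fluoro on an aromatic carbon, and no measured pair makes this exact exchange.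

The nearest evidence comes from replacing the whole 3-fluorophenyl group. Among the compounds with values here, one such replacement gave an at least 3.6-fold lower number from compound 1 to compound 2 (0.56 log units; beyond the scatter), and the 4-(dimethylamino)phenyl group of compound 2 supplies the only true number here. The other gave a step that the two limits leave unreadable from compound 1 to compound 3, while the reverse contrast between the two replacements is an at least 3.6-fold higher number from compound 2 to compound 3 (0.56 log units; beyond the scatter). Compound 4 retains the phenyl ring and has no 4-(dimethylamino)phenyl group, so it stays closer to compound 1 than compound 2 does. No step beyond the scatter is therefore expected in this assay, and a further limit is the likeliest report.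

Compound 4 is expected at about 12000 nM, with an estimated range of 4000 nM to 30000 nM. The estimated change is a step that the limit leaves unreadable from compound 1 to compound 4.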

Compound 4, half-maximal inhibitory concentration: 9330 nM
The estimate for compound 4 lay 1.3-fold (0.11 log units) above the measured number; low and high end bracket the measured number.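

In this assay, going by these compounds alone, trifluoromethyl in place of fluoro, on an aromatic carbon meta to a large group, gives the first true number for a compound that keeps the phenyl ring without a 4-(dimethylamino) group. The change reads as an at least 1.0-fold lower number from compound 1 to compound 4 (0.03 log units; that floor lies within the scatter), so the data allow a step of any size from that floor upward, and they do not establish a real change at this position. Compound 1 still carries only a limit, so the true size of the step cannot be read: the limit of > 10000 nM in this assay, at which 2 of the 4 values shown sit.

The compounds shown leave open whether a chloro, nitrile or methyl group on the same aromatic carbon would also give a number in this assay, or would stay at the limit. They also leave open whether trifluoromethyl would read the same elsewhere on the ring, so nothing here shows that this position, rather than the group alone, matters for the result.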